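Aryl ring swap in a cytotoxic discodermolide-type series

This account rests on a few compounds, and the source may have more. Where it says the series, first, only, none or still open, it means among the compounds named here.

Measured compounds:
Compound 1, `C=C/C=C\[C@H](C)[C@H](OC(N)=O)[C@@H](C)[C@H](O)[C@@H](C)C/C(C)=C\[C@H](C)[C@@H](O)[C@@H](C)/C=C\CCc1ccc(C)c(F)c1`, in a functional assay on A549 cells (Homo sapiens) for cytotoxicity; a higher number here means a weaker inhibitor, a lower number a stronger inhibitor: 4000 nM
Compound 2, `C=C/C=C\[C@H](C)[C@H](OC(N)=O)[C@@H](C)[C@H](O)[C@@H](C)C/C(C)=C\[C@H](C)[C@@H](O)[C@@H](C)/C=C\CCc1ccc(C)c(O)c1`, in this assay: 4000 nM

Compound 2 stands level with compound 1 on the numbers shown; the step of no change at the digits printed from compound 1 to compound 2 (within the scatter) lies within the scatter, so the two cannot be ordered. Compound 3, `C=C/C=C\[C@H](C)[C@H](OC(N)=O)[C@@H](C)[C@H](O)[C@@H](C)C/C(C)=C\[C@H](C)[C@@H](O)[C@@H](C)/C=C\CCc1cc(O)cc(O)c1`, has not yet been measured in this assay. It differs from compound 2 by 3,5-dihydroxyphenyl in place of 3-hydroxy-4-methylphenyl on a saturated chain carbon, two bonds along the chain from a double-bonded chain carbon.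

For the measured compounds named here, only one measured step exists, the one from compound 1 to compound 2, and it alters the same aromatic ring that is altered here, exchanging one substituent on that ring without moving the half-maximal inhibitory concentration beyond the scatter. Going by the values given here, no step exchanges the 4-methyl or adds a second hydroxy, so the present change is not directly covered. Among the compounds with values here, with the single bearing step being flat, no step beyond the scatter is expected in this assay, in either direction.

Compound 3 is therefore expected to give about 4000 nM in this assay, with a likely range from 1500 nM to 12000 nM, an estimated step of no change at the digits printed from compound 2 to compound 3 (within the scatter) from compound 2.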

Compound 3, half-maximal inhibitory concentration: 310 nM
The estimate for compound 3 lay 13-fold (1.11 log units) above the measured number; measured number below the stated range.
By their numbers in this assay, from the lowest: compound 3; then compounds 1 and 2 (each within the scatter of the next).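

In this assay, the aromatic group on a saturated chain carbon, two bonds along the chain from a double-bonded chain carbon, proves able to shift the half-maximal inhibitory concentration well beyond the scatter: 3,5-dihydroxyphenyl in place of 3-hydroxy-4-methylphenyl gives a 13-fold lower number from compound 2 to compound 3 (1.11 log units; beyond the scatter), and the same group in place of 3-fluoro-4-methylphenyl gives a 13-fold lower number from compound 1 to compound 3 (1.11 log units; beyond the scatter). The earlier pair showed only a flat exchange of fluoro for hydroxy on an aromatic carbon, whereas the two new steps show that this ring is not indifferent to its substitution and that 3,5-dihydroxyphenyl sets compound 3 apart from both compounds carrying a 4-methyl group. The compounds shown offer no measurement that bears on why the number falls.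

Going by these compounds, the exchange alters the ring as a whole, so it remains open whether the lower number follows from the loss of the 4-methyl group, the second hydroxy group, or their arrangement, which a plain 3-hydroxyphenyl or 4-hydroxyphenyl group could help separate. On these data alone, it is also open whether methoxy or amino groups in place of the two hydroxy groups of compound 3 would keep its number in this assay.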